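Methyl in place of hydrogen across two cores

The source may report more compounds than this note shows. Statements on the series, on what has been measured and on what is new or still open speak of the compounds shown alone.

Three compounds of this series have been run in a functional assay on A549 cells (Homo sapiens) for cytotoxicity, read by MTT assay, with a stated time of 48 h; on this read-out lower numbers stand for stronger inhibition and higher numbers for weaker inhibition. Compound 3 `COc1cc(COCc2cn(Cc3cc(-c4ccccc4)cnc3Cl)nn2)cc(OC)c1OC` gives 62600 nM. Compound 1 `COc1cc(COCc2cn(Cc3cc(-c4ccc(C)cc4)cnc3Cl)nn2)cc(OC)c1OC` differs from compound 3 by methyl in place of hydrogen on an aromatic carbon; in this assay compound 1 gives 150000 nM, and the step is a 2.4-fold higher number from compound 3 to compound 1 (0.38 log units; beyond the scatter). Compound 2 `COc1cc(C2=NOC(COCc3cn(Cc4cc(-c5ccccc5)cnc4Cl)nn3)C2)cc(OC)c1OC` carries a different core; the difference between the core of compound 2 and the core of compound 3 is not broken down here. In this assay compound 2 gives 8600 nM, the lowest number of the three, beyond the scatter against both compound 3 and compound 1.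

Compound 4 `COc1cc(C2=NOC(COCc3cn(Cc4cc(-c5ccc(C)cc5)cnc4Cl)nn3)C2)cc(OC)c1OC` has not yet been measured. It differs from compound 2 by methyl in place of hydrogen on an aromatic carbon. In both cases the methyl enters on an aromatic carbon of a six-membered aromatic ring of carbon only, para to a large group, so this is the same change as that from compound 3 to compound 1, now made on the core of compound 2. For the measured compounds named here, only one earlier instance of this change is available, so the expectation rests on a single step. Going by the values given here, for compound 4 the step is expected to be a 2.3-fold higher number from compound 2 to compound 4 (0.37 log units; beyond the scatter), close in size to the earlier one, because a 2.4-fold higher number from compound 3 to compound 1 (0.38 log units; beyond the scatter) is the only guide in hand. On that basis compound 4 is estimated at 20000 nM in this assay, with a range from 8000 nM to 50000 nM. From the compounds shown here alone, whether the change carries over to the second core remains open until compound 4 is measured.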

Compound 4, half-maximal inhibitory concentration: 11500 nM
Beside the measured number, compound 4's estimate is 1.7-fold (0.24 log units) above it, within the range that was stated.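

In this assay, phenyl to 4-methylphenyl on the core of compound 2 gives a 1.3-fold higher number from compound 2 to compound 4 (0.13 log units; within the scatter), so on this core the change leaves no readable difference. Set beside the step on the core of compound 3, the new step cannot be told apart from it: the same change on two cores in this assay, a 2.4-fold higher number (0.38 log units; beyond the scatter) from compound 3 to compound 1 and a 1.3-fold higher number (0.13 log units; within the scatter) from compound 2 to compound 4, 1.8-fold (0.25 log units) apart, within the scatter of two such steps. This fits a change that carries between these two cores as far as the assay can resolve, but it rests on one pair per core in a single cell assay, and it shows neither that the step has one shared size on both cores nor that it would hold on any further core.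

The compounds shown leave open whether a different group at the same place on the phenyl ring, such as methoxy, chlorine, an amine or a carboxylic acid, would give steps that stay alike on the two cores or that separate them. Also open, from the compounds shown here alone, is whether a longer chain there, in place of methyl, would give a step beyond the scatter on the core of compound 2, and whether the match between the two steps would hold in cells other than the A549 line.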